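A few compounds are considered here, and "the series" means these few. Any claim that something is new, unique, unknown or untested is made for them only; others in the source may bear on it.

Measured so far:
- Compound 1 `Clc1ccncc1C1=CC2CNCC(C1)C2` gives 3 nM in an in vitro assay on SH-EP1 cells for displacement of a labelled ligand from Neuronal acetylcholine receptor; alpha4/beta2 (Homo sapiens); a lower number here means a stronger inhibitor, a higher number a weaker inhibitor.
- Compound 2 `CN1CC2C=C(c3cnccc3Cl)CC(C2)C1` gives 1160 nM in this assay.
- Compound 3 `Fc1ccc(C2=CC3CNCC(C2)C3)cn1` gives 0.4 nM in this assay.

Compound 1 and compound 2 differ by methyl in place of hydrogen on an amine nitrogen in a ring, and this single change costs a 390-fold higher number from compound 1 to compound 2 (2.59 log units; beyond the scatter) in this assay, a large step well beyond the scatter. Compound 3 carries a different aromatic group on the shared core; how its core differs from that of compound 1 is not broken down here. Among the three measured compounds, compound 3 has the lowest number, and its steps to compound 1 and compound 2 both lie beyond the scatter.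

Compound 4 `CN1CC2C=C(c3ccc(F)nc3)CC(C2)C1` is the unmeasured partner of compound 3, differing from it by methyl in place of hydrogen on an amine nitrogen in a ring. The place of the change is the same, word for word, as from compound 1 to compound 2, so this is the same change. Since that change produced a 390-fold higher number from compound 1 to compound 2 (2.59 log units; beyond the scatter) in this assay, a step of similar size is expected here, estimated as a 380-fold higher number from compound 3 to compound 4 (2.57 log units; beyond the scatter). For compound 4 the expected value in this assay is 150 nM, with a range from 30 nM to 700 nM.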

Compound 4, inhibition constant: 18 nM
The estimate for compound 4 lay 8.3-fold (0.92 log units) above the measured number, outside the stated range (below it).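

Methyl in place of hydrogen on the amine nitrogen in the ring gives a higher number on both cores in this assay, and the new pair shows a 45-fold higher number from compound 3 to compound 4 (1.65 log units; beyond the scatter), so the direction carries over from one core to the other but the size does not: the same change on two cores in this assay, a 390-fold higher number (2.59 log units; beyond the scatter) from compound 1 to compound 2 and a 45-fold higher number (1.65 log units; beyond the scatter) from compound 3 to compound 4, 8.6-fold (0.93 log units) apart, beyond the scatter of two such steps

A step measured on one core therefore gave the direction of the step on the other core in this series, but not a size that can be transferred directly. Two pairs do not show which feature of the cores sets the size of the step, and they give no rule for a further core.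

On these data alone, it remains open how the number moves with an ethyl or a cyclopropylmethyl group on the same nitrogen, and whether the step then keeps its direction on both cores. Also open, as far as these compounds go, is how large the methyl step would be on a core whose aromatic group carries a methoxy group or an amine in place of the chlorine or fluorine.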